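A few compounds are considered here, and "the series" means these few. Any claim that something is new, unique, unknown or untested is made for them only; others in the source may bear on it.

Measured compounds:
compound 1, `CCCCc1oc2ccc(/N=C/c3ccc(Cl)cc3)cc2c1C(=O)c1ccc(OC)cc1`, in a functional assay, with a stated time of 30 min (on this read-out lower numbers stand for stronger inhibition and higher numbers for weaker inhibition), compound 1 gives 75.9 ug/mL
compound 2, `CCCCc1oc2ccc(/N=C/c3ccc([N+](=O)[O-])cc3)cc2c1C(=O)c1ccc(OC)cc1`, in this assay compound 2 gives 53.1 ug/mL

For the measured compounds named here, compound 2 has the lowest of the two numbers so far, but its only neighbour is compound 1, and the step of a 1.4-fold lower number from compound 1 to compound 2 (0.16 log units; within the scatter) falls within the scatter of repeated measurements, so the two compounds cannot be told apart on these numbers.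

Compound 3, `CCCCc1oc2ccc(/N=C/c3ccc(Cl)cc3Cl)cc2c1C(=O)c1ccc(OC)cc1`, is not yet measured. It differs from compound 2 in one place: 2,4-dichlorophenyl in place of 4-nitrophenyl on a carbon with a double bond to nitrogen. Going by the values given here, the one measured step that bears on this change is a 1.4-fold lower number from compound 1 to compound 2 (0.16 log units; within the scatter), which exchanged the group on that same carbon and moved the number only within the scatter. Among the compounds with values here, no measured pair shows what a second chlorine on that ring does, so this part of the change has no precedent here.

The expected step is therefore a 1.3-fold higher number from compound 2 to compound 3 (0.12 log units; within the scatter), a small move towards a higher number that stays within the scatter. For compound 3 the estimate is 70 ug/mL, with a range from 30 ug/mL to 160 ug/mL.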

Compound 3, half-maximal inhibitory concentration: 2.44 ug/mL
Beside the measured number, compound 3's estimate is 29-fold (1.46 log units) above it, and the stated range ends above it.
By their numbers in this assay, from the lowest: compound 3; then compounds 2 and 1 (each within the scatter of the next).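

In this assay, the ring on the carbon with a double bond to nitrogen proves able to move the number far more than the earlier chloro-to-nitro exchange suggested: 2,4-dichlorophenyl in place of 4-nitrophenyl gives a 22-fold lower number from compound 2 to compound 3 (1.34 log units; beyond the scatter) and so sets compound 3 clearly apart. For the compounds shown here, the closest comparison is with compound 1, where only one change separates the structures, chloro in place of hydrogen on an aromatic carbon, and this gives a 31-fold lower number from compound 1 to compound 3 (1.49 log units; beyond the scatter) on the same read-out, so a single added chlorine on this ring is enough for a large step. Nothing available here explains why this one added atom has so large an effect.

The compounds shown leave open whether chlorine itself is needed, or whether a fluoro, a methyl or a methoxy group at the same place on the ring would give a similar number. They also leave open whether the added chlorine would still matter with the other chlorine replaced by hydrogen, or with an amine or a carboxylic acid on that ring.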